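Furan-to-phenyl swap on the heteroaryl ketone series

The source may hold more compounds than are shown below. What is called first, only, known or untested is meant among the compounds shown, and "the series" means these compounds.

Working notes. Compound 1 `CCCCCCCC/C=C\CCCCCCC(=O)c1ncc(-c2ccco2)o1` carries a furan-2-yl group on the shared core and, in an assay on isolated protein for inhibition of Fatty-acid amide hydrolase 1 (Homo sapiens) (on this read-out higher numbers stand for weaker inhibition and lower numbers for stronger inhibition), compound 1 gives 54 nM, which is the only number shown in the set. Compound 2 `CCCCCCCC/C=C\CCCCCCC(=O)c1ccccc1` replaces the whole core with a plain aromatic ring, and in this assay compound 2 returns only a limit, > 100000 nM; this is the limit at which one of the two values sits, (the limit of > 100000 nM in this assay, at which 1 of the 2 values shown sits), and it stands as a limit, not a number. Among the measured compounds shown here, no step between two measured compounds differing in one place is available.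

From the compounds shown here alone, compound 3 `CCCCCCCC/C=C\CCCCCCC(=O)c1ncc(-c2ccccc2)o1` is untested. The change from compound 1 is phenyl in place of furan-2-yl on an aromatic carbon. The step is expected to be modest, weaker or flat within the scatter, estimated as a 2.0-fold higher number from compound 1 to compound 3 (0.31 log units; beyond the scatter). Compound 3 is therefore expected to show about 110 nM in this assay, with a range from 25 nM to 450 nM.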

Compound 3, inhibition constant: 320 nM
Compound 3: middle estimate off by 2.9-fold (0.46 log units), on the low side, and the stated range covers the measured number.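

In this assay, phenyl in place of furan-2-yl on this aromatic carbon gives a 5.9-fold higher number from compound 1 to compound 3 (0.77 log units; beyond the scatter), so the group at this position, next to the ring oxygen, changes the read-out beyond the scatter. Compound 3 still gives a measured number rather than a limit, so a six-membered aromatic ring of carbon only keeps measurable inhibition here, though weaker than with the five-membered aromatic ring with 1 hetero atom. No measurement shown bears on why the step arises.

With only these two groups compared at this carbon, ring size and the ring oxygen cannot be told apart as the source of the step. From the compounds shown here alone, how a pyridyl ring, a thiophene, an amine or a carboxylic acid at the same carbon would read in this assay remains open.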